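The source may report more compounds than this note shows. Statements on the series, on what has been measured and on what is new or still open speak of the compounds shown alone.

Within the data shown here, compound 1 `Cc1ccc(NC(=O)CCCCc2cn(Cc3ccc4oc(-c5ccc(Cl)cc5)cc(=O)c4c3)nn2)cc1` sits at the top of the three numbers measured so far: in an assay on isolated protein for inhibition of Amine oxidase [flavin-containing] B (Homo sapiens), read by fluorescence and spectrophotometry (on this read-out higher numbers stand for weaker inhibition and lower numbers for stronger inhibition), compound 1 gives 32900 nM. Compound 3 `Cc1ccc(NC(=O)CCCCc2cn(Cc3ccc4oc(-c5ccccc5)cc(=O)c4c3)nn2)cc1` gives 15600 nM, and compound 2 `O=C(NCc1cn(Cc2ccc3oc(-c4ccccc4)cc(=O)c3c2)nn1)c1ccccc1` gives 15600 nM; compound 2 and compound 3 lie within the scatter of each other, so no order between them is claimed. Among the measured compounds shown here, the only single-point step among the measured compounds runs a 2.1-fold lower number from compound 1 to compound 3 (0.32 log units; beyond the scatter), hydrogen in place of chloro on an aromatic carbon.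

Compound 4 `Cc1ccc(NC(=O)CCc2cn(Cc3ccc4oc(-c5ccc(Cl)cc5)cc(=O)c4c3)nn2)cc1` keeps the chloro and shortens the chain that joins the amide to the triazole: a group of 10 heavy atoms (8 carbon, 1 nitrogen, 1 oxygen; one six-membered aromatic ring of carbon only) in place of a group of 12 heavy atoms (10 carbon, 1 nitrogen, 1 oxygen; one six-membered aromatic ring of carbon only), on a saturated chain carbon, two bonds along the chain from an aromatic carbon. For the measured compounds named here, none of the measured steps bears directly on this change. The step from compound 1 to compound 3 concerns only the chloro substituent, which stays in place here, and compound 2 differs from compound 3 in more than one place, so the gap between their values cannot be read as a single change. Going by the values given here, with no precedent for the chain length in this set, the expectation for compound 4 in this assay is a step of a 1.3-fold lower number from compound 1 to compound 4 (0.12 log units; within the scatter), not clearly beyond the scatter in either direction. Compound 4 is therefore estimated at 25000 nM, with a range from 8000 nM to 80000 nM.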

Compound 4, half-maximal inhibitory concentration: 32900 nM
For compound 4 the middle estimate is 1.3-fold (0.12 log units) below the measured one; low and high end bracket the measured number.
By their numbers in this assay, from the lowest: compounds 2 and 3 (each within the scatter of the next); then compounds 1 and 4 (each within the scatter of the next).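

In this assay the change at this position gives no change at the digits printed from compound 1 to compound 4 (within the scatter): with the chloro kept, (4-methylphenyl)carbamoyl on the saturated chain carbon, two bonds along the chain from an aromatic carbon, reads the same as the group of 12 heavy atoms it replaces. Among these compounds, this is the first single-place step that touches the chain rather than the chloro substituent, and unlike the step of a 2.1-fold lower number from compound 1 to compound 3 (0.32 log units; beyond the scatter), it stays within the scatter, so this shortening shows no measurable effect on the number in this pair. No evidence at hand accounts for this result.

Still open, as far as these compounds go, is whether the same shortening leaves the number unchanged with hydrogen in place of chloro on the aromatic carbon, and whether a longer chain at this position, or a carboxylic acid or an amine in place of the (4-methylphenyl)carbamoyl group, would move the number in this assay. The finding rests on a single pair with the chloro present, so no trend with chain length can be drawn from it.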